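Shortening the Alcohol Chain of Compound 1

The source may hold more compounds than are shown below. What is called first, only, known or untested is meant among the compounds shown, and "the series" means these compounds.

Going by the values given here, in an in vitro ADME assay on microsomes from Gut (Homo sapiens) for metabolic stability, in the presence of a further agent that is not named here (a lower number here means slower removal, a higher number faster removal of the compound), compound 1 (`CC(C)(CO)CNC(=O)c1cc2cc(C#N)ccc2n1Cc1cccc(OC(F)(F)F)c1`) gives 136 mL.min-1.g-1, the highest of the three numbers so far. Compound 2 (`COc1ccc(OC(F)(F)F)cc1Cn1c(C(=O)NCC(C)(C)CO)cc2cc(C#N)ccc21`) gives 68 mL.min-1.g-1, and compound 3 (`CCCOc1cccc(Cn2c(C(=O)NCC(C)(C)CO)cc3cc(C#N)ccc32)c1`) gives 45 mL.min-1.g-1. Methoxy in place of hydrogen on an aromatic carbon makes a 2.0-fold lower number from compound 1 to compound 2 (0.30 log units; within the scatter). Propyl in place of trifluoromethyl on an oxygen on an aromatic ring makes a 3.0-fold lower number from compound 1 to compound 3 (0.48 log units; beyond the scatter).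

Compound 4 (`CC(O)CCNC(=O)c1cc2cc(C#N)ccc2n1Cc1cccc(OC(F)(F)F)c1`) instead has 2-hydroxypropyl in place of 1-(hydroxymethyl)-1-methylethyl on a saturated chain carbon bound to an amide-type nitrogen. Neither measured step alters this chain, so neither gives a direct guide to its effect. With no evidence for a direction, the expected result is no shift beyond the scatter in this assay, and the estimated step is a 1.1-fold lower number from compound 1 to compound 4 (0.05 log units; within the scatter). For compound 4, the estimated value is 120 mL.min-1.g-1, with an expected range from 55 mL.min-1.g-1 to 250 mL.min-1.g-1.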

Compound 4, intrinsic clearance in microsomes: < 6 mL.min-1.g-1
Compound 4: only a limit was reported (the forecaster's own chance of this, stated with the estimate: 2%); middle value at least 20-fold (1.30 log units) from the limit.
By their numbers in this assay, from the lowest: compounds 3, 2 and 1 (each within the scatter of the next, the first and the last beyond it). At a limit, below all of these: compound 4.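

Both earlier steps left the amide side chain untouched, so only now does this position show its weight in this assay. Putting 2-hydroxypropyl in place of 1-(hydroxymethyl)-1-methylethyl on a saturated chain carbon bound to an amide-type nitrogen gives an at least 22-fold lower number from compound 1 to compound 4 (1.35 log units; beyond the scatter), even though 4 heavy atoms enter where 5 leave and the hydrogen-bond donor and acceptor counts stay the same. The reading for compound 4 is a limit of the assay, not a number: the limit of < 6 mL.min-1.g-1 in this assay, at which 1 of the 4 values shown sits.

Going by these compounds, with a single new chain in view, it remains open how a longer chain, an amine or a carboxylic acid in this place would read. The data do not show what produces so large a step. Also open, on these data alone, is whether the same chain change would carry over to compound 2 or compound 3.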